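The source may hold more compounds than are shown below. What is called first, only, known or untested is meant among the compounds shown, and "the series" means these compounds.

Compound 1 `C=C1CCC[C@H]2[C@](C)(CC[C@]3(C)CC[C@@H]([C@@H](C)C(=O)O)OO3)[C@@H](C)CC[C@]12C` is measured in a functional assay on CAKI-1 cells (Homo sapiens) for inhibition (on this read-out higher numbers stand for weaker inhibition of growth and lower numbers for stronger inhibition of growth), where compound 1 gives 600 nM. Compound 2 `C=C1CCCC(C)(C)C1(O)CC/C(C)=C/CC[C@]1(C)CC[C@@H]([C@@H](C)C(=O)OC)OO1` gives only a limit in this assay, > 17500 nM. Among the compounds with values here, of the two readings, one is thus (the limit of > 17500 nM in this assay, at which 1 of the 2 values shown sits), so compound 1 holds the only plain number. Compound 3 `C=C1CCC[C@H]2[C@](C)(CC[C@]3(C)CC[C@H]([C@@H](C)C(=O)O)OO3)[C@@H](C)CC[C@]12C` is the next step: the two compounds have the same atoms and bonds and differ only in configuration as drawn: 1 of 7 stereo elements differ; a stereocentre at a saturated ring carbon is drawn S in compound 1 and R in compound 3. Within the data shown here, no measured step of this kind is at hand, so the expectation is a modest loss for compound 3, estimated as a 2.0-fold higher number from compound 1 to compound 3 (0.30 log units; within the scatter). Compound 3 is therefore expected at 1200 nM, likely between 300 nM and 6000 nM.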

Compound 3, concentration for 50% growth inhibition: 1760 nM
The estimate for compound 3 lay 1.5-fold (0.17 log units) below the measured number, within the range that was stated.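

In this assay, within the data shown here, turning this one saturated ring carbon from S to R gives a 2.9-fold higher number from compound 1 to compound 3 (0.47 log units; beyond the scatter), the first readable step at this position. The gap can be tied to this centre alone because nothing else in the structure changes: the fact that compounds 1 and 3 differ only in the configuration as drawn. The configuration here therefore affects the read-out, yet the change is modest, and compound 3 still gives a plain number, 1760 nM.

Open, from the compounds shown here alone, is how much the other stereo elements count. Also open, going by these compounds, is whether an amide in place of the carboxylic acid would show the same gap between S and R.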